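A few compounds are considered here, and "the series" means these few. Any claim that something is new, unique, unknown or untested is made for them only; others in the source may bear on it.

Compound 1, `CCOC(=O)[C@]1(C(=O)Nc2ccccc2Cl)C[C@@H]1c1cc(OC)c(OC)c(OC)c1`, in a functional assay on SW480 cells (Homo sapiens) for cytotoxicity, read by MTT assay, with a stated time of 48 h (on this read-out higher numbers stand for weaker inhibition and lower numbers for stronger inhibition), gives > 100000 nM, which is a limit of the assay and not a number. Compound 2, `CCOC(=O)[C@@]1(C(=O)Nc2ccccc2Cl)C[C@H]1c1cc(OC)c(OC)c(OC)c1`, gives 30100 nM. Compound 3, `CCOC(=O)[C@]1(C(=O)Nc2ccccc2Cl)C[C@H]1c1cc(OC)c(OC)c(OC)c1`, gives 25600 nM.

Compound 2 stands highest of the two numbers in this assay, and compound 3 lies a 1.2-fold lower number from compound 2 to compound 3 (0.07 log units; within the scatter) away from it, a gap within the scatter, so no order can be read between the two. Compound 1 gives only a limit (the limit of > 100000 nM in this assay, at which 1 of the 3 values shown sits); it differs from compound 2 solely in configuration (the fact that compounds 1 and 2 differ only in the configuration as drawn), and the step is an at least 3.3-fold lower number from compound 1 to compound 2 (0.52 log units; beyond the scatter). Against compound 3 the step is an at least 3.9-fold lower number from compound 1 to compound 3 (0.59 log units; beyond the scatter), again a change of configuration alone (the fact that compounds 1 and 3 differ only in the configuration as drawn).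

Compound 4, `COc1cc([C@@H]2C[C@@]2(CO)C(=O)Nc2ccccc2Cl)cc(OC)c1OC`, differs from compound 2 in another way: hydroxymethyl in place of ethoxycarbonyl on a saturated ring carbon. Among the measured compounds shown here, none of the measured steps touches a group at all; all three concern configuration only, so no measured step bears on this change and no direction can be drawn from them. Compound 4 is therefore expected to sit near compound 2, at an estimated 30000 nM with a range of 6000 nM to 120000 nM. The step expected for compound 4 is a 1.0-fold lower number from compound 2 to compound 4 (0.00 log units; within the scatter), with wide uncertainty.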

Compound 4, half-maximal inhibitory concentration: 10700 nM
Compound 4: the middle estimate sits 2.8-fold (0.45 log units) above what was measured, and the stated range covers the measured number.
By their numbers in this assay, from the lowest: compound 4; then compounds 3 and 2 (each within the scatter of the next). At a limit, above all of these: compound 1.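

In this assay, among the compounds shown here, hydroxymethyl in place of ethoxycarbonyl on a saturated ring carbon gives a 2.8-fold lower number from compound 2 to compound 4 (0.45 log units; beyond the scatter), the only step here that changes a group rather than the configuration as drawn. It shows that the number responds to the group at this position, next to the ring atom that bears a large group, and that the ethoxycarbonyl group is not required for the cytotoxicity seen with compound 2, since the step runs modestly towards stronger inhibition. Nothing given here accounts for this change, so its cause stays unassigned.

Going by these compounds, whether hydroxymethyl would give a similar step in the configurations of compound 1 and compound 3 remains open. Also open, on these data alone, is how a carboxylic acid, an amine or a longer hydroxyalkyl chain would behave at this position.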